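The source may hold more compounds than are shown below. What is called first, only, known or untested is meant among the compounds shown, and "the series" means these compounds.

Three compounds that share a core were measured in a physicochemical assay for solubility, in phosphate buffer, at pH 6.8; a higher number here means a more soluble compound, a lower number a less soluble compound. Compound 1 `O=C(C1=C(O)C(=O)N(c2ccc(-c3ccon3)cc2)C1C1CCCCC1)c1ccc(CO)cc1` reaches the limit of the assay, giving > 50000 nM. Compound 2 `COc1ccccc1C1C(C(=O)C(C)(C)C)=C(O)C(=O)N1c1ccc(-c2ccon2)cc1` gives 29600 nM in this assay. Compound 3 `Cc1cc(-c2ccc(N3C(=O)C(O)=C(C(=O)C(C)(C)C)C3c3ccccc3OCCO)cc2)on1` also sits at the limit of this assay, giving > 50000 nM, so for it only a boundary is known and not a number. Where compound 3 stands is therefore described by the limit of > 50000 nM in this assay, at which 2 of the 3 values shown sit, and its gap to compound 2 cannot be sized, one side being only a limit.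

Compound 4 `Cc1noc(-c2ccc(N3C(=O)C(O)=C(C(=O)C(C)(C)C)C3c3ccccc3OCCO)cc2)n1` differs from compound 3 in a single place: 3-methyl-1,2,4-oxadiazol-5-yl in place of 3-methyl-1,2-oxazol-5-yl on an aromatic carbon. Going by the values given here, no pair of measured compounds differs in just one place, so no measured step guides this change. Both the group that leaves and the group that enters are small five-membered aromatic rings, and in this assay a change no larger than the scatter, in either direction, is expected from swapping one for the other. Since compound 3 already sits at the limit, compound 4 is expected to give about 60000 nM in this assay, within a range of 25000 nM to 150000 nM, most likely reported again as a limit rather than a number. The step from compound 3 to compound 4 that this estimate implies, a step that the limit leaves unreadable from compound 3 to compound 4, is expected to be none beyond the scatter.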

Compound 4, solubility: > 50000 nM
Compound 4 gave a limit, no number; the forecaster's own chance of this, stated with the estimate: 65%; the middle value does not contradict the limit.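

Compound 3 and compound 4 each give a limit rather than a number in this assay, and no step between them can be read because both rest on the same boundary: the limit of > 50000 nM in this assay, at which 3 of the 4 values shown sit.

Left open is how soluble either compound really is, and whether 3-methyl-1,2,4-oxadiazol-5-yl in place of 3-methyl-1,2-oxazol-5-yl changes that at all.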